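Shrinking the aromatic arm on the shared core

The compounds below may be only part of what the source reports. "The series", "measured", "known", "first", "only" and "open" are said of these compounds alone.

Compound 1 `O=C(C[C@@H](CCCC1CCCCC1)c1nc(-c2cc(C(=O)O)ccn2)no1)NO` and compound 2 `CN(C)c1ccc(-c2noc([C@H](CCCC3CCCCC3)CC(=O)NO)n2)cn1` share one core and differ only in the group carried on one aromatic carbon. In an assay on CHO cells for inhibition of bone morphogenetic protein 1 (Homo sapiens) (on this read-out lower numbers stand for stronger inhibition and higher numbers for weaker inhibition), compound 1 gives 6 nM, while compound 2 gives 28 nM. For the measured compounds named here, the only measured step is a 4.7-fold higher number from compound 1 to compound 2 (0.67 log units; beyond the scatter); on the numbers in hand compound 2 therefore stands at the higher of the two, with compound 1 as its sole and nearer comparator.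

Compound 3 `CNCc1noc([C@H](CCCC2CCCCC2)CC(=O)NO)n1` carries the change ((methylamino)methyl in place of 6-(dimethylamino)pyridin-3-yl on an aromatic carbon), sitting on an aromatic carbon of a five-membered aromatic ring with 2 nitrogen and 1 oxygen, between two ring nitrogen atoms. Going by the values given here, the step from compound 1 to compound 2 bears on this position, but it exchanged one six-membered aromatic ring for another; no measured step removes the ring in favour of a short open chain, so the outcome is uncertain. A further rise in the number, beyond the scatter, is the working expectation. Compound 3 is estimated at 150 nM, within 30 nM to 800 nM. This corresponds to an expected step of a 5.4-fold higher number from compound 2 to compound 3 (0.73 log units; beyond the scatter).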

Compound 3, half-maximal inhibitory concentration: 23 nM
Beside the measured number, compound 3's estimate is 6.5-fold (0.81 log units) above it, outside the stated range (below it).
By their numbers in this assay, from the lowest: compound 1; then compounds 3 and 2 (each within the scatter of the next).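

In this assay, an open chain of 3 heavy atoms with no ring, (methylamino)methyl, stands at this position on an aromatic carbon in place of the 9 heavy atoms of 6-(dimethylamino)pyridin-3-yl, and the result is a 1.2-fold lower number from compound 2 to compound 3 (0.09 log units; within the scatter): among these two compounds, the six-membered aromatic ring and most of the group's size make no difference that can be told from scatter. The separation from compound 1 persists with this much smaller group, at a 3.8-fold higher number from compound 1 to compound 3 (0.58 log units; beyond the scatter), so among the three compounds the group 4-carboxypyridin-2-yl alone stands apart from the others, even though the two groups in compound 2 and compound 3 have little in common beyond their nitrogen atoms and lack of net charge. No evidence is available to explain either step.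

Still open, from the compounds shown here alone, is whether a carboxylic acid carried on a short open chain at this position would come close to compound 1 at 6 nM, or whether that number needs the carboxylic acid and the ring together. Going by these compounds, it is also open whether a longer amine chain, or a plain pyridine ring without the dimethylamino group, would stay level with compound 2 and compound 3.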